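The compounds below may be only part of what the source reports. "The series", "measured", "known", "first", "only" and "open" are said of these compounds alone.

Measured in a functional assay on MNK45 cells (Homo sapiens) for inhibition, read by MTT assay, with a stated time of 48 h; on this read-out lower numbers stand for stronger inhibition and higher numbers for weaker inhibition:

Compound 1 `Cc1ccc(NC(=S)NC(=O)c2ccc(OCc3ccc(Cl)cc3Cl)cc2)cc1-c1nc2ccccc2[nH]1` gives 5300 nM.
Compound 2 `Cc1ccc(NC(=S)NC(=O)c2ccc(OCc3ccc(F)cc3)cc2)cc1-c1nc2ccccc2[nH]1` gives 4220 nM.
Compound 3 `Cc1ccc(NC(=O)NC(=O)c2ccc(OCc3ccc(Cl)cc3Cl)cc2)cc1-c1nc2ccccc2[nH]1` gives 2550 nM.

Compounds 1 and 2 share one core and differ in a single place: 4-fluorophenyl in place of 2,4-dichlorophenyl on a saturated chain carbon bound to an oxygen on an aromatic ring. On this change the number moves by a 1.3-fold lower number from compound 1 to compound 2 (0.10 log units; within the scatter), a step that does not stand out from the usual scatter of the measurement. Compound 3 carries a different core; how the core of compound 3 differs from the core of compound 1 is not broken down here. Compound 3 shows the lowest of the three numbers; its gap to compound 1 lies beyond the scatter, while its gap to compound 2 does not.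

Compound 4 `Cc1ccc(NC(=O)NC(=O)c2ccc(OCc3ccc(F)cc3)cc2)cc1-c1nc2ccccc2[nH]1` is derived from compound 3 by the same change that led from compound 1 to compound 2: 4-fluorophenyl in place of 2,4-dichlorophenyl on a saturated chain carbon bound to an oxygen on an aromatic ring. Since the earlier step was small, the step from compound 3 to compound 4 in this assay is expected to be of a similar size, a 1.3-fold lower number from compound 3 to compound 4 (0.11 log units; within the scatter), resting on a 1.3-fold lower number from compound 1 to compound 2 (0.10 log units; within the scatter). Compound 4 is therefore estimated at 2000 nM, with a likely range from 1000 nM to 4500 nM.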

Compound 4, half-maximal inhibitory concentration: 240 nM
Compound 4: the middle estimate sits 8.3-fold (0.92 log units) above what was measured; the whole stated range lies above it.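

In this assay, putting 4-fluorophenyl in place of 2,4-dichlorophenyl on a saturated chain carbon bound to an oxygen on an aromatic ring gives an 11-fold lower number from compound 3 to compound 4 (1.03 log units; beyond the scatter), a large step on the core of compound 3. Among these compounds, the size of this change therefore did not carry over from one core to the other, and the step on the core of compound 1 was a poor guide to the step on the core of compound 3: the same change on two cores in this assay, a 1.3-fold lower number (0.10 log units; within the scatter) from compound 1 to compound 2 and an 11-fold lower number (1.03 log units; beyond the scatter) from compound 3 to compound 4, 8.5-fold (0.93 log units) apart, beyond the scatter of two such steps This shows that, for these two cores, the effect of the change depends on the core it sits on, but with only one pair of compounds on each core it does not show which feature of the cores is responsible or how the change would behave on a third core.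

The compounds shown leave open whether the large step comes from losing the chlorine atoms or from gaining the fluorine atom. A plain phenyl group or a cyclohexyl group on the same chain carbon, set on both cores, would bear on that question.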